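The source may hold more compounds than are shown below. What is called first, only, known or untested is meant among the compounds shown, and "the series" means these compounds.

Compound 3 `COC(=O)c1cc(-c2cccc(NC(=O)c3ccc(/C=C/C(=O)c4ccccc4C)cc3)c2)on1` carries a 2-methylphenyl on the carbonyl carbon of the enone. In an ADME assay on Vero cells (Chlorocebus sabaeus) for cytotoxicity, read by MTT assay, with a stated time of 72 h (on this read-out lower numbers stand for higher toxicity in this test and higher numbers for lower toxicity in this test), compound 3 gives > 25 ug/mL, which is a limit of the assay and not a number. Compound 1 `COC(=O)c1cc(-c2cccc(NC(=O)c3ccc(/C=C/C(=O)c4cccc(C(F)(F)F)c4)cc3)c2)on1` in this assay gives > 20 ug/mL, again a limit. Compound 2 `COC(=O)c1cc(-c2cccc(NC(=O)c3ccc(/C=C/C(=O)c4cc(F)ccc4F)cc3)c2)on1` in this assay gives > 40 ug/mL, also a limit. Compound 3 therefore stands among three values that are all limits; (the limit of > 20 ug/mL in this assay, at which 1 of the 3 values shown sits), the limit of > 25 ug/mL in this assay, at which 1 of the 3 values shown sits, and the limit of > 40 ug/mL in this assay, at which 1 of the 3 values shown sits, mark where each sits, and no ordering of the three can be read from them. The step that the two limits leave unreadable from compound 1 to compound 3 and the step that the two limits leave unreadable from compound 2 to compound 3 both end at compound 3, and a step that the two limits leave unreadable from compound 1 to compound 2 joins the other two; none has a readable size.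

Compound 4 `COC(=O)c1cc(-c2cccc(NC(=O)c3ccc(/C=C/C(=O)c4ccc(C)cc4)cc3)c2)on1` differs from compound 3 by 4-methylphenyl in place of 2-methylphenyl on a carbonyl carbon. All three measured steps are exchanges of the aryl group on the same carbonyl carbon, so they bear on this change, yet each is unreadable between two limits. The step that the limit leaves unreadable from compound 3 to compound 4 is expected to lie within the usual scatter, and compound 4 will most likely again be reported as a limit. Compound 4 is estimated at 40 ug/mL, in the range 15 ug/mL to 100 ug/mL.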

Compound 4, half-maximal cytotoxic concentration: > 80 ug/mL
Compound 4 was reported as a limit (the forecaster's own chance of this, stated with the estimate: 80%); middle value at least 2.0-fold (0.30 log units) away from the limit.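

Compound 4 also returns a limit of the assay and not a number in this assay: > 80 ug/mL. Its steps to compound 1, compound 2 and compound 3 all run between two limits, so no new step can be read. The compounds shown leave open whether exchanging the aryl group on the carbonyl carbon changes the half-maximal cytotoxic concentration at all.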